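The source may report more compounds than this note shows. Statements on the series, on what has been measured and on what is new or still open speak of the compounds shown alone.

Among the compounds with values here, in a functional assay on MDCK cells (Canis lupus familiaris) for antiproliferative activity (a lower number here means a stronger inhibitor, a higher number a weaker inhibitor), compound 1 `COc1ccc(/C=C2/C(C)=C(CC(=O)O)c3cc(F)ccc32)cc1` gives 310000 nM, the only number it has there; one further entry for it carries no single number. Compound 2 `CC1=C(CC(=O)O)c2cc(F)ccc2/C1=C\c1ccc(C)o1` gives 310000 nM; 60000 nM (2 entries), recorded as repeated entries (the several entries of compound 2 in this assay, 310000 nM; 60000 nM (2 entries)). Compound 3 `CC1=C(CC(=O)O)c2cc(F)ccc2/C1=C\c1cccs1` has not been measured and carries thiophen-2-yl in place of 4-methoxyphenyl on a double-bonded chain carbon bound to a double-bonded ring carbon. Within the data shown here, no measured pair shows the weight of this change, so in this assay only a small step is expected, no larger than the usual scatter in either direction. Compound 3 is therefore estimated at 200000 nM, with a likely range from 40000 nM to 600000 nM. This means an expected step of a 1.6-fold lower number from compound 1 to compound 3 (0.19 log units; within the scatter) that stays within the scatter.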

Compound 3, half-maximal inhibitory concentration: 80000 nM
Compound 3: the middle estimate sits 2.5-fold (0.40 log units) above what was measured, and the stated range covers the measured number.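

In this assay, within the data shown here, swapping 4-methoxyphenyl for thiophen-2-yl gives a 3.9-fold lower number from compound 1 to compound 3 (0.59 log units; beyond the scatter) and so offers the first sign that the group at this position affects the read-out. The smaller five-membered ring is at least tolerated here. The step is modest, and it calls for caution because repeated entries in this assay can lie far apart: the several entries of compound 2 in this assay, 310000 nM; 60000 nM (2 entries).

Going by these compounds, it remains open whether the sulfur-containing ring, the smaller ring size or the loss of the methoxy group drives the step. An unsubstituted phenyl group at this position could help separate these possibilities.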